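A methylphenyl swap at a cytotoxicity limit

The source may hold more compounds than are shown below. What is called first, only, known or untested is meant among the compounds shown, and "the series" means these compounds.

Of the compounds shown here, three sharing one core have been tested in a functional assay on U-937 cells (Homo sapiens) for cytotoxicity, read by MTT assay, with a stated time of 48 h; on this read-out higher numbers stand for weaker inhibition and lower numbers for stronger inhibition. In this assay, compound 1 `COc1ccc(Nc2nc(-c3cccc(F)c3)nc3ccc(F)cc23)cc1` gives 41100 nM. Compound 2 `Fc1cccc(-c2nc(Nc3ccccc3Cl)c3cc(F)ccc3n2)c1` gives only a limit, > 50000 nM. Compound 3 `Nc1cccc(Nc2nc(-c3cccc(F)c3)nc3ccc(F)cc23)c1` also gives only a limit, > 50000 nM, so its place on the scale is not a number. That reading is the limit of > 50000 nM in this assay, at which 2 of the 3 values shown sit.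

Compound 4 `Cc1ccccc1Nc1nc(-c2cccc(F)c2)nc2ccc(F)cc12` has 2-methylphenyl in place of 3-aminophenyl on a nitrogen on an aromatic ring. Going by the values given here, three measured steps bear on this change, since all of them alter the same place. They are an at least 1.2-fold higher number from compound 1 to compound 2 (0.08 log units; that floor lies within the scatter), an at least 1.2-fold higher number from compound 1 to compound 3 (0.08 log units; that floor lies within the scatter) and a step that the two limits leave unreadable from compound 2 to compound 3. None of them gives a firm size, and none shows a change beyond the scatter. No step beyond the scatter is therefore expected in this assay, and another limit reading is the likeliest result. The expected change is a number no higher from compound 3 to compound 4 (the limit leaves the size open). Compound 4 is estimated at 50000 nM, with an expected range of 28000 nM to 90000 nM.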

Compound 4, half-maximal inhibitory concentration: > 50000 nM
Compound 4: only a limit was reported; the forecaster's own chance of this, stated with the estimate: 65%; the middle value sits exactly at the limit.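

In this assay compound 4 gives > 50000 nM, which is a limit and not a number. Going by these compounds alone, the steps from compound 4 to compound 2 and to compound 3 cannot be read, as both ends of each are limits, and the only readable step is an at least 1.2-fold higher number from compound 1 to compound 4 (0.08 log units; that floor lies within the scatter). So 2-methylphenyl on this nitrogen brings no reading clear of the limit, and neither does methyl in place of chloro on that aromatic carbon, which adds a third substituted phenyl group to those at the limit: the limit of > 50000 nM in this assay, at which 3 of the 4 values shown sit.

As far as these compounds go, how compound 2, compound 3 and compound 4 rank among themselves stays open, as does how far any of them truly lies from compound 1. Also open, from the compounds shown here alone, is whether a carboxylic acid or a longer chain ending in an amine on this phenyl ring would give a reading clearly apart from compound 1.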